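The source may hold more compounds than are shown below. What is called first, only, known or untested is meant among the compounds shown, and "the series" means these compounds.

Measured so far:
compound 1 `Cc1ccc2c(c1NS(C)(=O)=O)CCC2c1ncc[nH]1` gives 33 nM
compound 2 `CCS(=O)(=O)Nc1cccc2c1CCC2c1ncc[nH]1` gives 32 nM
compound 3 `Clc1ccc2c(c1-c1ccn[nH]1)CCC2c1ncc[nH]1` gives 322 nM

In a functional assay on CHO cells for agonist activity at Alpha-1A adrenergic receptor (Homo sapiens), read by FLIPR and calcium flux (on this read-out higher numbers stand for an effect only at larger amounts of compound and lower numbers for an effect already at smaller amounts), compound 2 stands lowest of the three numbers, although its gap to compound 1 lies within the scatter, so no order between the two can be claimed. Compound 3 sits well beyond the scatter above both of them. Compound 4 `c1cncc(-c2cccc3c2CCC3c2ncc[nH]2)c1` has not been measured. It departs from compound 2 by one change: pyridin-3-yl in place of (ethylsulfonyl)amino on an aromatic carbon. For the measured compounds named here, no step between two measured compounds isolates this exact exchange. The sulfonamide-bearing compounds 1 and 2 sit close together, whereas compound 3, which carries an aromatic ring in place of a sulfonamide, gives the higher number, so compound 4 is expected to move upward by a step of a 4.7-fold higher number from compound 2 to compound 4 (0.67 log units; beyond the scatter), likely beyond the scatter. Compound 4 is therefore estimated at 150 nM, with a range from 45 nM to 500 nM.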

Compound 4, half-maximal effective concentration: 2060 nM
The estimate for compound 4 lay 14-fold (1.14 log units) below the measured number; the measured number lies above the stated range.
By their numbers in this assay, from the lowest: compounds 2 and 1 (each within the scatter of the next); then compound 3; then compound 4.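

In this assay, placing pyridin-3-yl instead of (ethylsulfonyl)amino on this aromatic carbon gives a 64-fold higher number from compound 2 to compound 4 (1.81 log units; beyond the scatter). Both groups count six heavy atoms, so heavy-atom count alone does not set the number at this position, while the exchange also removes the hydrogen-bond donor and adds a ring, and this single step cannot separate those changes. No measurement shown accounts for the size of the step. As far as these compounds go, whether an amine, an acetylamino group or a phenyl ring on this carbon would stay near compound 2 or near compound 4 remains open.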